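Cyclopropyl for Methyl on the Triazole of Compound 2

The source may hold more compounds than are shown below. What is called first, only, known or untested is meant among the compounds shown, and "the series" means these compounds.

Going by the values given here, compound 2 `Cc1nnc(CN(C)C)n1-c1ccc(Cl)cc1C(=O)c1ccccc1Cl` gives 50 mg/kg in a functional assay on the whole organism (strain CF-1) for inhibition, with Mus musculus as the target (on this read-out higher numbers stand for an effect only at larger amounts of compound and lower numbers for an effect already at smaller amounts), the highest of the two numbers measured, while compound 1 `Cc1nnc(CN(C)C)n1-c1ccc(Cl)cc1C(=O)c1ccccc1` gives 45 mg/kg; the single measured step, a 1.1-fold higher number from compound 1 to compound 2 (0.05 log units; within the scatter), lies within the scatter. Compound 3 `CN(C)Cc1nnc(C2CC2)n1-c1ccc(Cl)cc1C(=O)c1ccccc1Cl` carries cyclopropyl in place of methyl on an aromatic carbon. Among the compounds with values here, no measured step touches this position, so nothing in the data points in either direction, and the expected step of no change at the digits printed from compound 2 to compound 3 (within the scatter) is none beyond the scatter. For compound 3 the estimate in this assay is 50 mg/kg, with a range from 20 mg/kg to 125 mg/kg.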

Compound 3, dose for half-maximal effect: 79 mg/kg
For compound 3 the middle estimate is 1.6-fold (0.20 log units) below the measured one; the range from low to high includes it.
By their numbers in this assay, from the lowest: compounds 1, 2 and 3 (each within the scatter of the next).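

In this assay, cyclopropyl in place of methyl on the aromatic carbon between two ring nitrogen atoms gives a 1.6-fold higher number from compound 2 to compound 3 (0.20 log units; within the scatter) and so stays within the scatter. Going by these compounds alone, this is the first look at this position, and it shows that the ring-bearing group is accommodated there without a step beyond the scatter. No evidence bears on this result.

On these data alone, what remains open is how an amine, a longer chain such as butyl, or a phenyl ring at this position would read in this assay. As far as these compounds go, it is also open whether cyclopropyl gives a similar step on compound 1.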